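From Carbamoyl to Dichlorophenyl Ketone on a Shared Core

The source may report more compounds than this note shows. Statements on the series, on what has been measured and on what is new or still open speak of the compounds shown alone.

All three measured compounds sit at the edge of what an assay for inhibition of Polyunsaturated fatty acid lipoxygenase ALOX15 (Homo sapiens), with a stated time of 10 min (on this read-out higher numbers stand for weaker inhibition and lower numbers for stronger inhibition), can report. Compound 1 `Nc1[nH]c(C(=O)c2ccccc2)c(-c2c(F)cccc2F)c1C(=O)c1ccc(Cl)c(Cl)c1` gives in this assay > 100000 nM, a limit of the assay rather than a number. Compound 2 `NC(=O)c1c(N)[nH]c(C(=O)c2ccccc2)c1-c1ccc(Cl)cc1Cl` gives in this assay > 100000 nM, which is likewise only a limit. Compound 3 `Nc1[nH]c(C(=O)c2ccccc2)c(-c2ccncc2)c1C(=O)c1cccc(Cl)c1` gives in this assay > 100000 nM, again a limit. Compound 2 therefore stands where every other measured compound stands, at the limit of > 100000 nM in this assay, at which 3 of the 3 values shown sit, and nothing on the numbers shown separates it from compounds 1 and 3.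

Compound 4 `Nc1[nH]c(C(=O)c2ccccc2)c(-c2ccc(Cl)cc2Cl)c1C(=O)c1ccc(Cl)c(Cl)c1` has not yet been measured in this assay. It differs from compound 2 in one place: 3,4-dichlorophenyl in place of amino on a carbonyl carbon. The group that enters, as (3,4-dichlorophenyl)carbonyl, is already present on the shared core of compound 1, and compound 1 gives in this assay only the limit > 100000 nM. Among the measured compounds shown here, no step between measured compounds is available, so no measured pair tells the size or direction of this change. The step from compound 2 to compound 4 is expected to be none beyond the scatter, with both at the limit: a number no higher from compound 2 to compound 4 (the limit leaves the size open). Compound 4 is expected to give 100000 nM in this assay, within a range from 30000 nM to 300000 nM, and most likely to be reported as a limit only.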

Compound 4, half-maximal inhibitory concentration: 12800 nM
Compound 4: middle estimate off by 7.8-fold (0.89 log units), on the high side; the whole stated range lies above it.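

In this assay, only compound 4 reads as a number and not as a limit of the assay: the limit of > 100000 nM in this assay, at which 3 of the 4 values shown sit.

On the carbonyl carbon, 3,4-dichlorophenyl in place of amino, which turns carbamoyl into (3,4-dichlorophenyl)carbonyl, gives an at least 7.8-fold lower number from compound 2 to compound 4 (0.89 log units; beyond the scatter). On the aromatic carbon, 2,4-dichlorophenyl in place of 2,6-difluorophenyl gives an at least 7.8-fold lower number from compound 1 to compound 4 (0.89 log units; beyond the scatter). Neither group brings a readable value alone, as compound 1 carries the (3,4-dichlorophenyl)carbonyl and compound 2 the 2,4-dichlorophenyl, and both remain at the limit; among these compounds a number appears only where the two groups stand together in compound 4.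

As far as these compounds go, the true size of both steps stays open, with compound 1 and compound 2 known only as limits, and the printed steps give only the least that each change can amount to. Also open, from the compounds shown here alone, is whether the two chlorine atoms on the entering ring are needed, as a plain phenyl, a 4-chlorophenyl or a methyl on the same carbonyl carbon would show whether a number still appears with the 2,4-dichlorophenyl in place.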